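The source may report more compounds than this note shows. Statements on the series, on what has been measured and on what is new or still open speak of the compounds shown alone.

Of the compounds shown here, three sharing one core have been measured in a functional assay on EC9706 cells (Homo sapiens) for antiproliferative activity, read by MTT assay, with a stated time of 72 h; a lower number here means a stronger inhibitor, a higher number a weaker inhibitor. Compound 1 `O=C(N/N=C/c1ccco1)c1cccc(S(=O)(=O)N2CCOCC2)c1` carries a furan-2-yl on the carbon with a double bond to nitrogen, and in this assay compound 1 reaches only > 100000 nM, which is a limit of the assay and not a number (the limit of > 100000 nM in this assay, at which 1 of the 3 values shown sits). Compound 2 `O=C(N/N=C/c1ccccc1O)c1cccc(S(=O)(=O)N2CCOCC2)c1` has a 2-hydroxyphenyl on that carbon, and in this assay compound 2 gives 19600 nM. Compound 3 `COc1ccc(/C=N/NC(=O)c2cccc(S(=O)(=O)N3CCOCC3)c2)c(O)c1` has a 2-hydroxy-4-methoxyphenyl there, and in this assay compound 3 gives 1090 nM, the lowest of the two numbers shown. The step of an 18-fold lower number from compound 2 to compound 3 (1.25 log units; beyond the scatter) is large, an at least 91-fold lower number from compound 1 to compound 3 (1.96 log units; beyond the scatter) is larger still, and an at least 5.1-fold lower number from compound 1 to compound 2 (0.70 log units; beyond the scatter) is at least modest.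

Compound 4 `CCOc1cccc(/C=N/NC(=O)c2cccc(S(=O)(=O)N3CCOCC3)c2)c1O` is not yet measured. It differs from compound 3 in one place: 3-ethoxy-2-hydroxyphenyl in place of 2-hydroxy-4-methoxyphenyl on a carbon with a double bond to nitrogen. The hydroxyl is kept, the methoxy leaves and an ethoxy enters. For the measured compounds named here, no measured step covers this exchange directly; the step of an 18-fold lower number from compound 2 to compound 3 (1.25 log units; beyond the scatter) shows that the methoxy of compound 3 mattered greatly, but whether an ethoxy in a different position gives the same gain is unknown, so a number between those of compound 2 and compound 3 seems most likely. The expected step of a 4.6-fold higher number from compound 3 to compound 4 (0.66 log units; beyond the scatter) therefore points toward a weaker inhibitor. Compound 4 is estimated at 5000 nM, with a range from 1000 nM to 25000 nM.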

Compound 4, half-maximal inhibitory concentration: 15400 nM
Estimate against measurement, compound 4: 3.1-fold (0.49 log units) below; the range from low to high includes it.
By their numbers in this assay, from the lowest: compound 3; then compounds 4 and 2 (each within the scatter of the next). At a limit, above all of these: compound 1.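

In this assay, the addition of an ethoxy group gives a 1.3-fold lower number from compound 2 to compound 4 (0.10 log units; within the scatter), so this addition brings no change that can be told apart from the scatter. The large gain from the methoxy of compound 3 therefore does not extend to every such ether group on this ring: 3-ethoxy-2-hydroxyphenyl in place of 2-hydroxy-4-methoxyphenyl gives a 14-fold higher number from compound 3 to compound 4 (1.15 log units; beyond the scatter), a large step for an exchange that adds little to the size of the group. The exchange with furan-2-yl gives an at least 6.4-fold lower number from compound 1 to compound 4 (0.81 log units; beyond the scatter), and this size can be read only as a bound because the value of compound 1 is a limit of the assay and not a number: the limit of > 100000 nM in this assay, at which 1 of the 4 values shown sits.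

Since the group and its place on the ring change together in this exchange, the compounds shown cannot tell whether the loss follows from ethoxy replacing methoxy or from the new place on the ring, which a 3-methoxy-2-hydroxyphenyl or a 4-ethoxy-2-hydroxyphenyl would separate. From the compounds shown here alone, it also stays open how a longer chain such as propoxy, or an amine such as dimethylamino, would behave in the place held by the methoxy of compound 3.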